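The source may report more compounds than this note shows. Statements on the series, on what has been measured and on what is new or still open speak of the compounds shown alone.

Working notes on the series. In a functional assay on U-87MG ATCC cells (Homo sapiens) for cytotoxicity, read by MTT assay, with a stated time of 48 h (on this read-out higher numbers stand for weaker inhibition and lower numbers for stronger inhibition), compound 1 `C/C(=N\NC(=S)Nc1ccc(Cl)cc1)c1ccccn1` gives 1.7 nM, level with compound 3 `C/C(=N/NC(=S)Nc1ccc(Cl)cc1)c1ccccn1` at 1.7 nM, and these two share the lowest number of the three measured. Compound 2 `CC(=NNC(=S)Nc1cccc(F)c1)c1ccccn1` gives 18 nM, a higher number, with fluoro rather than chloro on its aromatic ring.

Compound 4 `C/C(=N\NC(=S)Nc1ccccc1)c1ccccn1` has hydrogen in place of chloro on an aromatic carbon, para to a large group, relative to compound 1 (hydrogen in place of chloro on an aromatic carbon). Among the measured compounds shown here, the single measured step shows no change at the digits printed from compound 1 to compound 3 (within the scatter). It concerns (the fact that compounds 1 and 3 differ only in the configuration as drawn), so it gives no size for losing the chloro. For the measured compounds named here, the only guide is compound 2, which also lacks chloro and stands at 18 nM against 1.7 nM for compound 1, although the two are not single-change neighbours. A move to a higher number in this assay, beyond the scatter, is therefore expected, with low confidence in its size. The estimated step is a 7.1-fold higher number from compound 1 to compound 4 (0.85 log units; beyond the scatter). For compound 4 the expected value is 12 nM, with an estimated range from 3 nM to 50 nM.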

Compound 4, half-maximal inhibitory concentration: 1.4 nM
Estimate against measurement, compound 4: 8.6-fold (0.93 log units) above, outside the stated range (below it).
By their numbers in this assay, from the lowest: compounds 4, 1 and 3 (each within the scatter of the next); then compound 2.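

Among the compounds shown here, replacing chloro with hydrogen on the aromatic carbon para to a large group gives a 1.2-fold lower number from compound 1 to compound 4 (0.08 log units; within the scatter) in this assay, the first direct reading of this change at this position. For this pair, the chloro is therefore not required to hold the number at this low level, and a single aromatic chlorine can leave without a change beyond the scatter. Nothing measured here bears on why the number holds when the chloro leaves.

As far as these compounds go, it remains open whether other groups on this same carbon, such as methoxy, an amine or a carboxylic acid, would also leave the number in place. From the compounds shown here alone, it is also open whether the hydrogen compound would match its counterpart of opposite double-bond configuration, as compounds 1 and 3 do.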